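A few compounds are considered here, and "the series" means these few. Any claim that something is new, unique, unknown or untested is made for them only; others in the source may bear on it.

Measured compounds in a physicochemical assay for solubility, in phosphate buffer, measured as kinetic solubility, with a stated time of 1 h, at pH 7.4; a lower number here means a less soluble compound, a higher number a more soluble compound:

- compound 1, `CC(C)(c1cc([C@]23CCOC[C@H]2C3)nc(-c2cccc(O)c2)n1)S(C)(=O)=O`: 135 ug/mL
- compound 2, `CC(C)(c1cc([C@]23CCOC[C@H]2C3)nc(-c2ccc(NC(=S)NCCO)cc2)n1)S(C)(=O)=O`: 173 ug/mL
- compound 3, `Oc1cccc(-c2nccc(C34CCOCC3C4)n2)c1`: 102 ug/mL

Compound 3 carries the smallest of the three numbers, but its gap to compound 1 and its gap to compound 2 both lie within the scatter of this assay, so on these figures none of the three can be set apart from the others. Compound 4, `Oc1cccc(-c2nccc([C@]34CCOC[C@H]3C4)n2)c1`, has not yet been measured in this assay. It differs from compound 3 only in how it is drawn: the two compounds have the same atoms and bonds; at least one stereo element is drawn with a configuration in one of them and without one in the other: 2 of 2 stereo elements differ; a stereocentre at a saturated ring carbon is drawn without a configuration in compound 3 and R in compound 4; a stereocentre at a saturated ring carbon is drawn without a configuration in compound 3 and S in compound 4. Within the data shown here, since the two compounds have the same atoms and bonds, there is no structural step here of the kind that has moved any number, and no step between measured compounds is available for comparison. The account therefore expects no change beyond the scatter from compound 3 to compound 4, that is, an expected step of no change at the digits printed from compound 3 to compound 4 (within the scatter) in this assay. For compound 4 the estimated value in this assay is 102 ug/mL, with an expected range from 60 ug/mL to 175 ug/mL.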

Compound 4, solubility: 141 ug/mL
Estimate against measurement, compound 4: 1.4-fold (0.14 log units) below; low and high end bracket the measured number.
By their numbers in this assay, from the lowest: compounds 3, 1, 4 and 2 (each within the scatter of the next).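

Among these compounds, the pair gives the first reading of a stereo difference with nothing else changed. In this assay, among the compounds shown here, the result is a 1.4-fold higher number from compound 3 to compound 4 (0.14 log units; within the scatter), and only one thing separates these two compounds: the fact that one of compounds 3 and 4 is drawn with a defined configuration and the other without, at the place where they differ The second pair gives the first reading at the aromatic carbon that carries 1-methyl-1-(methylsulfonyl)ethyl in compound 1: hydrogen in its place gives a 1.0-fold higher number from compound 1 to compound 4 (0.02 log units; within the scatter), so neither the drawn configuration nor this exchange can be told apart from repeat scatter in this assay.

The compounds shown leave open whether an amine or a carboxylic acid on that aromatic carbon would give a step beyond the scatter. As far as these compounds go, it also remains open whether the opposite configuration at the two saturated ring carbons would give a number different from that of compound 4.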